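Adding a second 3-methylbut-2-en-1-yl group to compound 1

The source may hold more compounds than are shown below. What is called first, only, known or untested is meant among the compounds shown, and "the series" means these compounds.

Among the measured compounds shown here, compound 1 `COc1cc(C2Oc3cc(-c4oc5cc(OCC=C(C)C)cc(O)c5c(=O)c4O)ccc3OC2CO)ccc1O` was tested in a functional assay for inhibition, read by spectrophotometry, with a stated time of 10 min (on this read-out lower numbers stand for an effect already at smaller amounts and higher numbers for an effect only at larger amounts of compound), where compound 1 gives 137000 nM, the highest of the three numbers measured so far. Compound 3 `CCN(CC)C(=O)COc1cc(O)c2c(=O)c(O)c(-c3ccc4c(c3)OC(c3ccc(O)c(OC)c3)C(CO)O4)oc2c1` differs from it in one place, and in this assay compound 3 gives 113000 nM, a change of a 1.2-fold lower number from compound 1 to compound 3 (0.08 log units; within the scatter). For the measured compounds named here, compound 2 `COc1cc(C2Oc3cc(-c4oc5cc(OCC(=O)N6CCCC6)cc(O)c5c(=O)c4O)ccc3OC2CO)ccc1OCC(=O)N1CCCC1`, which bears a group on both of the oxygens in question, gives 23200 nM in this assay, the lowest number so far; compound 2 differs from compound 1 in more than one place, so no single step can be read from it.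

Compound 4 `COc1cc(C2Oc3cc(-c4oc5cc(OCC=C(C)C)cc(O)c5c(=O)c4O)ccc3OC2CO)ccc1OCC=C(C)C` has not been measured. It differs from compound 1 in that (3-methylbut-2-en-1-yl in place of hydrogen on an oxygen on an aromatic ring). Going by the values given here, no measured pair changes exactly this one place. The step from compound 1 to compound 3 , a 1.2-fold lower number from compound 1 to compound 3 (0.08 log units; within the scatter), shows that exchanging one group for another barely moves the number, while the values of compound 2 and compound 3 suggest that occupying the second oxygen as well may lower it. Compound 4 is therefore expected to show a modest step, a 2.0-fold lower number from compound 1 to compound 4 (0.29 log units; within the scatter), toward a lower number. The estimate for compound 4 is 70000 nM, within a range from 25000 nM to 200000 nM.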

Compound 4, half-maximal effective concentration: 138000 nM
Beside the measured number, compound 4's estimate is 2.0-fold (0.29 log units) below it, within the range that was stated.
By their numbers in this assay, from the lowest: compound 2; then compounds 3, 1 and 4 (each within the scatter of the next).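

In this assay, changing hydroxy to (3-methylbut-2-en-1-yl)oxy on this oxygen on an aromatic ring gives a 1.0-fold higher number from compound 1 to compound 4 (0.00 log units; within the scatter). This is the first single step shown at this oxygen, since the earlier step changed the group on a different oxygen. At this position, then, the hydrogen of the hydroxy can give way to this unbranched-at-oxygen five-carbon group without any readable change in the number, though nothing at hand offers an explanation for that.

Going by these compounds, whether a methyl, or a chain ending in an amine or a carboxylic acid, would move the number at this oxygen stays open. Also open, on these data alone, is how much of the value of compound 2 comes from its group on this oxygen, as compound 2 differs from compound 1 in more than one place.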